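Adding a nitro group to the weakest anilide

The compounds below may be only part of what the source reports. "The series", "measured", "known", "first", "only" and "open" are said of these compounds alone.

In an assay on cells for antagonist activity at P2X purinoceptor 7 (Homo sapiens), read by fluorescence and calcium flux, with a stated time of 30 min (a higher number here means a weaker inhibitor, a lower number a stronger inhibitor), compound 2 `O=C(Nc1cccc(C(F)(F)F)c1)c1cc(Cl)ccc1O` gives 6320 nM, the highest of the two numbers recorded. Compound 1 `O=C(Nc1cc(C(F)(F)F)cc(C(F)(F)F)c1)c1cccc(Cl)c1O` gives 177 nM in this assay, a much lower number, though it differs from compound 2 in more than one place. Compound 3 `O=C(Nc1cc([N+](=O)[O-])cc(C(F)(F)F)c1)c1cc(Cl)ccc1O` differs from compound 2 by nitro in place of hydrogen on an aromatic carbon. For the measured compounds named here, no single-change step is known here, so the expectation rests only on the two recorded values. Compound 3 is expected to give 1500 nM in this assay, within 400 nM to 5000 nM, an estimated step from a 4.2-fold lower number from compound 2 to compound 3 (0.62 log units; beyond the scatter) toward a stronger inhibitor.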

Compound 3, half-maximal inhibitory concentration: 143 nM
The estimate for compound 3 lay 10-fold (1.02 log units) above the measured number; measured number outside the range, below it.
By their numbers in this assay, from the lowest: compounds 3 and 1 (each within the scatter of the next); then compound 2.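

In this assay the only single-change step shown is a 44-fold lower number from compound 2 to compound 3 (1.65 log units; beyond the scatter), so this aromatic carbon, meta to a trifluoromethyl group, need not carry hydrogen, and nitro here brings a large gain in inhibition. No measurement bearing on the cause of this step is available.

On these data alone, whether an amine, a carboxylic acid or a nitrile on this same carbon would give a comparable step remains open. So does whether nitro would have the same effect with the chlorine placed as in compound 1.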